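This account rests on a few compounds, and the source may have more. Where it says the series, first, only, none or still open, it means among the compounds named here.

Compound 1 `COc1cc(-c2nnc3n2NC(c2ccco2)C(C(=O)c2ccc(Br)cc2)S3)cc(OC)c1OC` gives 42100 nM in a functional assay on A549 cells (Homo sapiens) for cytotoxicity, read by MTT assay, with a stated time of 48 h; on this read-out higher numbers stand for weaker inhibition and lower numbers for stronger inhibition. Compound 2 `COc1cc(-c2nnc3n2NC(c2cccs2)C(C(=O)c2ccc(F)cc2)S3)cc(OC)c1OC` gives 45000 nM in this assay, and the two numbers sit within the usual scatter of each other. Compound 3 `COc1ccc(C(=O)C2Sc3nnc(-c4cc(OC)c(OC)c(OC)c4)n3NC2c2cccs2)cc1` reaches only the limit of the assay, > 100000 nM (the limit of > 100000 nM in this assay, at which 1 of the 3 values shown sits). Among the compounds with values here, the one counted step, an at least 2.2-fold higher number from compound 2 to compound 3 (0.34 log units; beyond the scatter), concerns methoxy in place of fluoro on an aromatic carbon. Compound 4 `COc1cc(-c2nnc3n2NC(c2ccco2)C(C(=O)c2ccc(C)cc2)S3)cc(OC)c1OC` differs from compound 1 by methyl in place of bromo on an aromatic carbon. No measured step covers bromo to methyl, so the expectation rests on how little the two numbers shown vary and on a step of a 1.2-fold higher number from compound 1 to compound 4 (0.07 log units; within the scatter) is expected. Compound 4 is therefore estimated at 50000 nM, within 25000 nM to 100000 nM.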

Compound 4, half-maximal inhibitory concentration: > 100000 nM
Compound 4 ended at the assay's limit; the forecaster's own chance of this, stated with the estimate: 25%; middle value at least 2.0-fold (0.30 log units) away from the limit.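

Even a swap of one heavy atom for one heavy atom matters at this position: methyl in place of bromo gives an at least 2.3-fold higher number from compound 1 to compound 4 (0.37 log units; beyond the scatter) in this assay. Until now only methoxy in place of fluoro had shown such a loss, so methyl is a second group here that gives weaker inhibition than the halogen it replaces. The full size of this step cannot be read, since the result for compound 4 is a limit and not a number: the limit of > 100000 nM in this assay, at which 2 of the 4 values shown sit.

From the compounds shown here alone, whether chloro at this position would match bromo remains open. So does the effect of an amine or a carboxylic acid there.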